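Amide side-chain terminus and antiproliferative potency on MCF7 cells

This account rests on a few compounds, and the source may have more. Where it says the series, first, only, none or still open, it means among the compounds named here.

Measured so far:
compound 1 `CCn1c(C(=O)NCCC(=O)OC)ccc1C(CC)(CC)c1ccc(OCS(=O)(=O)c2ccccc2)c(C)c1` — > 50000 nM
compound 2 `CCN(CC)CCNC(=O)c1ccc(C(CC)(CC)c2ccc(OCS(=O)(=O)c3ccccc3)c(C)c2)n1CC` — 4680 nM

Going by the values given here, in a functional assay on MCF7 cells (Homo sapiens) for antiproliferative activity, read by MTT assay, with a stated time of 24 h (a lower number here means a stronger inhibitor, a higher number a weaker inhibitor), compound 2 gives 4680 nM, the only number among the two values shown. Compound 1 gives > 50000 nM, which is a limit of the assay (the limit of > 50000 nM in this assay, at which 1 of the 2 values shown sits). Among the compounds with values here, the single measured step, an at least 10-fold lower number from compound 1 to compound 2 (1.02 log units; beyond the scatter), shows that replacing the ester terminus by the basic amine brings the series from a limit to a measurable number.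

Compound 3 `CCn1c(C(=O)NCCC(=O)O)ccc1C(CC)(CC)c1ccc(OCS(=O)(=O)c2ccccc2)c(C)c1` differs from compound 2 in that (carboxy in place of diethylamino on a saturated chain carbon, two bonds along the chain from an amide-type nitrogen). Within the data shown here, the one step that bears on this change is an at least 10-fold lower number from compound 1 to compound 2 (1.02 log units; beyond the scatter), which ran in the opposite direction and was large. Removing the diethylamino group is therefore expected to undo most of that gain, and a large upward step is expected, an 11-fold higher number from compound 2 to compound 3 (1.03 log units; beyond the scatter). Compound 3 is expected to give about 50000 nM, in the range 15000 nM to 150000 nM, with a good chance that only a limit is reported.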

Compound 3, half-maximal inhibitory concentration: > 50000 nM
Compound 3: no number, only a limit; the forecaster's own chance of this, stated with the estimate: 65%; the middle value lies on the limit itself.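

Compound 3 gives > 50000 nM in this assay, which is a limit of the assay and not a number. The step of an at least 10-fold higher number from compound 2 to compound 3 (1.02 log units; beyond the scatter) shows that the large difference at this position is not tied to the methoxycarbonyl terminus, since carboxy on the same saturated chain carbon also ends well away from the value of the diethylamino terminus. The step between the two non-amine termini cannot be read, and the series now gathers at one end of the range: the limit of > 50000 nM in this assay, at which 2 of the 3 values shown sit.

Still open, on these data alone, is whether the measurable value needs diethylamino itself or would also appear with another amine, such as dimethylamino or a piperidine, or with a neutral primary carboxamide. Also open, as far as these compounds go, is how a longer chain between the amide nitrogen and the diethylamino group would read.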